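The source may hold more compounds than are shown below. What is called first, only, known or untested is meant among the compounds shown, and "the series" means these compounds.

The shared core of the series carries a six-membered aromatic ring of carbon only, substituted on one aromatic carbon. Compound 1 `FC(F)(F)c1ccc(NC(=S)OCCc2ccccn2)cc1` carries trifluoromethyl there, and in an ADME assay on MT4 cells (Homo sapiens) for cytotoxicity, read by MTT assay (on this read-out lower numbers stand for higher toxicity in this test and higher numbers for lower toxicity in this test), compound 1 gives 50000 nM. Compound 2 `CC(=O)c1ccc(NC(=S)OCCc2ccccn2)cc1` carries acetyl there. In this assay compound 2 gives only a limit of the test, >= 100000 nM, and no number. The step of an at least 2.0-fold higher number from compound 1 to compound 2 (0.30 log units; that floor lies within the scatter) therefore rests on the limit of >= 100000 nM in this assay, at which 1 of the 2 values shown sits, and cannot be sized beyond that floor. Compound 3 `Fc1ccc(NC(=S)OCCc2ccccn2)cc1` is next in line: fluoro in place of acetyl on an aromatic carbon. Among the measured compounds shown here, only one measured step bears on this change, and that step from trifluoromethyl to acetyl was small, at its floor within the scatter. Fluoro at the same place is expected to leave the picture unchanged. The move an at least 1.4-fold lower number from compound 2 to compound 3 (0.15 log units; that floor lies within the scatter) is expected to stay within the scatter. For compound 3 the estimate in this assay is 70000 nM, with a range from 30000 nM to 150000 nM.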

Compound 3, half-maximal cytotoxic concentration: > 100000 nM
Compound 3 was reported as a limit; the forecaster's own chance of this, stated with the estimate: 45%; middle value at least 1.4-fold (0.15 log units) away from the limit.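

In this assay compound 3 gives only a limit of the test, > 100000 nM. Fluoro in place of trifluoromethyl gives an at least 2.0-fold higher number from compound 1 to compound 3 (0.30 log units; that floor lies within the scatter), so a second group at this position now ends in a limit, and compound 1 remains the only compound shown with a number. The step between the two limit compounds cannot be read, so fluoro and acetyl cannot be ordered here: the limit of > 100000 nM in this assay, at which 1 of the 3 values shown sits.

On these data alone, it remains open how far compound 2 and compound 3 lie past their limits, and so whether either truly differs from compound 1 by more than the scatter. As far as these compounds go, it also remains open whether an amine or a carboxylic acid on the same aromatic carbon would give a readable number in this assay.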